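One aryl swap on compound 3

The source may report more compounds than this note shows. Statements on the series, on what has been measured and on what is new or still open speak of the compounds shown alone.

In an ADME assay on HepG2 cells (Homo sapiens) for cytotoxicity (on this read-out lower numbers stand for higher toxicity in this test and higher numbers for lower toxicity in this test), compound 1 `CSc1cccc(N(C(=O)c2cc3ccc(C(F)(F)F)cc3[nH]2)[C@@H](C)C(=O)NC2CCCC2)c1` gives 7100 nM, and compound 2 `CSc1cccc(N(C(=O)c2cc3ccc(C(F)(F)F)cc3[nH]2)[C@H](C)C(=O)NC2CCCC2)c1` gives 15000 nM. The modest 2.1-fold higher number from compound 1 to compound 2 (0.32 log units; beyond the scatter) comes with the fact that compounds 1 and 2 differ only in the configuration as drawn. Compound 3 `CSc1cccc(N2C(=O)CN(c3ccc(C(F)(F)F)cc3)CC2C(=O)NC2CCCC2)c1` gives 10000 nM, within the scatter of both. Compound 4 `CSc1cccc(N2C(=O)CN(c3cccc(C#N)c3)CC2C(=O)NC2CCCC2)c1` differs from it by 3-cyanophenyl in place of 4-(trifluoromethyl)phenyl on an amine nitrogen in a ring. Going by the values given here, the only measured step is a change of configuration, so it bears on this swap only as a sign of how small differences can be. No step beyond the scatter is therefore expected in this assay, and the value of compound 3, 10000 nM, serves as the starting point. The expected change is a 1.2-fold higher number from compound 3 to compound 4 (0.08 log units; within the scatter). For compound 4, the estimated value is 12000 nM, with an expected range of 5500 nM to 28000 nM.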

Compound 4, half-maximal cytotoxic concentration: > 50000 nM
Compound 4 gave a limit, no number (the forecaster's own chance of this, stated with the estimate: 20%); at least 4.1-fold (0.61 log units) between middle value and limit.
By their numbers in this assay, from the lowest: compounds 1, 3 and 2 (each within the scatter of the next, the first and the last beyond it). At a limit, above all of these: compound 4.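

Going by these compounds alone, the earlier compounds showed only a change of configuration, whereas this is the first step at the amine nitrogen in the ring, and it shows that the group there matters in this assay. Placing 3-cyanophenyl in place of 4-(trifluoromethyl)phenyl gives an at least 5.0-fold higher number from compound 3 to compound 4 (0.69 log units; beyond the scatter). Compound 4 reads > 50000 nM, which is a limit of the assay and not a number.

The swap alters both the substituent and its place on the aromatic ring, so the compounds shown cannot separate these two changes. As far as these compounds go, how an unsubstituted phenyl group on that nitrogen would read also stays open.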